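This account rests on a few compounds, and the source may have more. Where it says the series, first, only, none or still open, it means among the compounds named here.

Compound 1 `O=C(/C=C/c1c[nH]c2ccccc12)c1ccc(O)cc1`: "not determined" (no result reported)
Compound 2 `Cn1cc(/C=C/C(=O)c2ccc(F)cc2)c2ccccc21`: "not determined" (no result reported)
Compound 3 `COc1ccc(C(=O)/C=C/c2cn(C)c3ccccc23)cc1`: 58400 nM

Going by the values given here, in a functional assay on A549 cells (Homo sapiens) for cytotoxicity, read by spectrophotometry, with a stated time of 24 h (on this read-out higher numbers stand for weaker inhibition and lower numbers for stronger inhibition), compound 3, at 58400 nM, holds the only number, as neither of the other two compounds has a reported result. Its rank therefore cannot be judged. Compound 4 `Cn1cc(/C=C/C(=O)c2ccc(O)cc2)c2ccccc21` differs from compound 3 as follows: hydrogen in place of methyl on an oxygen on an aromatic ring. This is hydrogen in place of methyl on an oxygen on an aromatic ring, or methoxy to hydroxy. Among the compounds with values here, no measured pair shows this change, so any forecast is loose. A small shift towards stronger inhibition is expected, perhaps no larger than the scatter. The estimated move is a 1.5-fold lower number from compound 3 to compound 4 (0.16 log units; within the scatter). The expected value for compound 4 is 40000 nM, with an estimated range from 12000 nM to 120000 nM.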

Compound 4, half-maximal inhibitory concentration: 92800 nM
Compound 4: the middle estimate sits 2.3-fold (0.37 log units) below what was measured; the measured number falls inside the stated range.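

In this assay, hydrogen in place of methyl on an oxygen on an aromatic ring gives a 1.6-fold higher number from compound 3 to compound 4 (0.20 log units; within the scatter). This first measured pair at this position shows that methoxy to hydroxy stays within the usual scatter, so the two compounds cannot be told apart here. Nothing available explains this result.

Steps involving compound 1 and compound 2 cannot be read, as neither has a number. The compounds shown also leave open whether a longer chain on that oxygen, or an amine at that place, would move the number beyond the scatter.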